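From compound 3 to compound 4: expected clearance

A few compounds are considered here, and "the series" means these few. Any claim that something is new, unique, unknown or untested is made for them only; others in the source may bear on it.

In an ADME assay on microsomes from liver (Homo sapiens) for metabolic stability (a higher number here means faster removal of the compound, a lower number slower removal), compound 3 `CSc1cc(-c2cnc(N)c(OC(F)F)n2)nc(N2C[C@@H]3C[C@H]2CO3)n1` gives 5.7 mL/min/kg. That value lies within the scatter of compound 1 `CCOC(=O)N1C[C@@H]2C[C@H]1CN2c1nc(-c2cnc(N)c(OC(F)F)n2)cc(N2CC3CC2C3)n1` at 11.1 mL/min/kg, while compound 2 `Nc1ncc(-c2cc([C@@H]3CCCO3)nc(N3C[C@@H]4C[C@H]3CO4)n2)nc1OC(F)F` at 12.6 mL/min/kg lies beyond the scatter from it. Compound 4 `Nc1ncc(-c2cc(N3CC4CC3C4)nc(N3C[C@@H]4C[C@H]3CO4)n2)nc1OC(F)F` has not yet been measured in this assay. The change from compound 3 is a group of 6 heavy atoms (5 carbon, 1 nitrogen; one four-membered non-aromatic ring of carbon only, one five-membered non-aromatic ring with 1 hetero atom) in place of a group of 2 heavy atoms (1 carbon, 1 sulfur; no ring), on an aromatic carbon, on an aromatic carbon.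

For the measured compounds named here, only one measured step bears directly on this position: a 2.2-fold lower number from compound 2 to compound 3 (0.34 log units; beyond the scatter), a modest step. Read in reverse, it shows a ring-bearing group giving a higher number than methylsulfanyl at this place. Compound 1 carries the same entering group and gives 11.1 mL/min/kg, but it also differs from compound 4 elsewhere, so it serves only as a rough guide. The expected change is a small upward one, a 1.8-fold higher number from compound 3 to compound 4 (0.24 log units; within the scatter). For compound 4 the estimated clearance is 10 mL/min/kg, with an expected range of 5.5 mL/min/kg to 19 mL/min/kg.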

Compound 4, clearance: 9.3 mL/min/kg
For compound 4 the middle estimate is 1.1-fold (0.03 log units) above the measured one, and the stated range covers the measured number.
By their numbers in this assay, from the lowest: compounds 3, 4, 1 and 2 (each within the scatter of the next, the first and the last beyond it).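

Replacing methylsulfanyl with the group of 6 heavy atoms gives a 1.6-fold higher number from compound 3 to compound 4 (0.21 log units; within the scatter) in this assay, so this larger two-ring group is not separated from methylsulfanyl at this aromatic carbon. Replacing oxolan-2-yl with the same group gives a 1.4-fold lower number from compound 2 to compound 4 (0.13 log units; within the scatter), which places it within the scatter of both groups, even though those two are separated by a 2.2-fold lower number from compound 2 to compound 3 (0.34 log units; beyond the scatter). No measurement available here accounts for these results.

As far as these compounds go, it remains open whether an open-chain amine such as dimethylamino, a carboxylic acid or a longer alkyl chain at this aromatic carbon would give a step beyond the scatter from compound 4. From the compounds shown here alone, it is also open whether these steps would hold with a different group elsewhere on the shared core.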